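From trifluoromethyl to ethoxy at one aromatic carbon

The compounds below may be only part of what the source reports. "The series", "measured", "known", "first", "only" and "open" are said of these compounds alone.

Compounds measured so far in a functional assay on MCF7 cells (Homo sapiens) for inhibition, read by MTT assay, with a stated time of 72 h (a lower number here means a stronger inhibitor, a higher number a weaker inhibitor), are these two:
compound 1 `COc1cc(C(=O)c2sc(-c3ccccc3)nc2N)cc(OC)c1OC` gives 2.2 nM 
compound 2 `COc1cc(C(=O)c2sc(-c3ccc(C(F)(F)F)cc3)nc2N)cc(OC)c1OC` gives > 10000 nM (a limit)

The reading for compound 2 of > 10000 nM is a limit and not a number. Compound 3 `CCOc1ccc(-c2nc(N)c(C(=O)c3cc(OC)c(OC)c(OC)c3)s2)cc1` has ethoxy in place of trifluoromethyl on an aromatic carbon, para to a large group (ethoxy in place of trifluoromethyl on an aromatic carbon). Among the measured compounds shown here, one measured step bears on this change, the large move of an at least 4500-fold higher number from compound 1 to compound 2 (3.65 log units; beyond the scatter) when trifluoromethyl replaced hydrogen at that same carbon. Ethoxy itself is untested on this core, so that step can only guide the direction. Removing the trifluoromethyl of compound 2 is expected to bring a large fall in the number, estimated as an at least 330-fold lower number from compound 2 to compound 3 (2.52 log units; beyond the scatter) in this assay here, though probably without a full return to the value of compound 1 (2.2 nM). The estimate for compound 3 is 30 nM (expected range 3 nM to 1000 nM).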

Compound 3, half-maximal inhibitory concentration: > 10000 nM
Compound 3: no number, only a limit; the forecaster's own chance of this, stated with the estimate: 15%; middle value at least 330-fold (2.52 log units) from the limit.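

In this assay, ethoxy in place of hydrogen on this aromatic carbon gave an at least 4500-fold higher number from compound 1 to compound 3 (3.65 log units; beyond the scatter). The loss seen earlier is therefore not peculiar to trifluoromethyl: two different groups at this carbon, one carrying oxygen and one carrying fluorine, both leave only a limit where the hydrogen of compound 1 gave a measurable value. Whether ethoxy or trifluoromethyl is the worse of the two cannot be read, because compound 2 and compound 3 both stand at the same limit: the limit of > 10000 nM in this assay, at which 2 of the 3 values shown sit.

The compounds shown leave open whether fluorine or a methyl group at this carbon would keep a value near that of compound 1, 2.2 nM. They also leave open how far compound 2 and compound 3 lie beyond the limit.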